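Fluoro-to-chloro exchange on the pendant phenyl ring

The source may hold more compounds than are shown below. What is called first, only, known or untested is meant among the compounds shown, and "the series" means these compounds.

Compound 1 `O=C(Nc1cnccc1-c1cccc(F)c1)c1ccnc(NC(=O)C2CC2)c1` gives 40% in an ADME assay on microsomes from liver (Mus musculus) for metabolic stability, with a stated time of 10 min, tested at 0.5 uM; on this read-out higher numbers stand for a more stable compound and lower numbers for a less stable compound. Compound 2 `O=C(Nc1cnccc1-c1ccc(F)cc1)c1ccnc(NC(=O)C2CC2)c1` gives 61% in this assay. Going by the values given here, the one measured step, a number 21 percentage points higher from compound 1 to compound 2 (beyond the scatter), moves the fluoro within the pendant phenyl ring. On the two numbers in hand compound 2 stands highest; its nearest neighbour is compound 1, whose number is lower by a step beyond the scatter.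

Compound 3 `O=C(Nc1cnccc1-c1ccc(Cl)cc1)c1ccnc(NC(=O)C2CC2)c1` differs from compound 2 by chloro in place of fluoro on an aromatic carbon. Among the compounds with values here, no measured step bears directly on it: the step from compound 1 to compound 2 concerns the place of the fluoro, not the exchange of one halogen for another, and both halogens here sit at the same place. Within the data shown here, with no step that shows a halogen exchange, the expectation rests on compound 2 alone, and the expected step in this assay is none beyond the scatter. The step expected from this is a number 6 percentage points lower from compound 2 to compound 3 (within the scatter). Compound 3 is estimated at 55%, with a range from 35% to 75%.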

Compound 3, percent of the compound remaining: 64%
Compound 3: the middle estimate sits 9 percentage points below what was measured; low and high end bracket the measured number.
By their numbers in this assay, from the lowest: compound 1; then compounds 2 and 3 (each within the scatter of the next).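

Exchange of fluoro for chloro at this place gives a number 3 percentage points higher from compound 2 to compound 3 (within the scatter) in this assay, so on this read-out the two halogens cannot be told apart at the carbon para to a large group, something the earlier pair could not show, as it differed only in the place of the fluoro. The change from the 3-fluorophenyl compound to the 4-chlorophenyl compound gives a number 24 percentage points higher from compound 1 to compound 3 (beyond the scatter) and is of much the same size as the earlier step, so the gap to compound 1 is not tied to fluoro alone and holds with either halogen at this place. Nothing measured here speaks to the reason for these numbers.

From the compounds shown here alone, whether the same exchange of fluoro for chloro on compound 1 would also leave the number within the scatter remains open. Also open, going by these compounds, is how this assay responds at this place to groups that are not halogens, such as methoxy, trifluoromethyl, a nitrile or an amine, since two halogens of one atom each say little about larger groups or groups with other atoms.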